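Imidazole substitution pattern in a diarylethane series

The source may hold more compounds than are shown below. What is called first, only, known or untested is meant among the compounds shown, and "the series" means these compounds.

Measured so far:
compound 1 `COc1ccc(Br)cc1CCc1ccccc1-c1ncc(C)n1C` — 51 nM
compound 2 `CCc1cn(C)c(-c2ccccc2CCc2cc(Br)ccc2OC)n1` — 820 nM

In a functional assay on HEK293 cells (Homo sapiens), read by cAMP accumulation (on this read-out lower numbers stand for stronger inhibition and higher numbers for weaker inhibition), compound 2 gives the higher of the two numbers, and the nearer neighbour is compound 1 at 51 nM. Compound 3 `COc1ccc(Br)cc1CCc1ccccc1-c1nc(C)c(C)n1C` follows: 1,4,5-trimethyl-1H-imidazol-2-yl in place of 4-ethyl-1-methyl-1H-imidazol-2-yl on an aromatic carbon. Among the measured compounds shown here, the one measured step that bears on it is a 16-fold higher number from compound 1 to compound 2 (1.21 log units; beyond the scatter), which exchanged two substituted imidazoles at the same position and was large. Compound 3 restores the 1,5-dimethyl pattern of compound 1 while keeping a group at the fourth ring position, so a move back toward compound 1 is expected, though not a full return. Compound 3 is thus estimated at 150 nM (range 50 nM to 500 nM), a step of a 5.5-fold lower number from compound 2 to compound 3 (0.74 log units; beyond the scatter).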

Compound 3, half-maximal inhibitory concentration: 200 nM
Compound 3: the middle estimate sits 1.3-fold (0.12 log units) below what was measured; the measured number falls inside the stated range.
By their numbers in this assay, from the lowest: compound 1; then compound 3; then compound 2.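

In this assay, a 3.9-fold higher number from compound 1 to compound 3 (0.59 log units; beyond the scatter) shows that one added methyl on the imidazole is enough to weaken inhibition beyond the scatter. The exchange of 4-ethyl-1-methyl-1H-imidazol-2-yl for 1,4,5-trimethyl-1H-imidazol-2-yl gives a 4.1-fold lower number from compound 2 to compound 3 (0.61 log units; beyond the scatter), so with the same atoms in both groups, their arrangement on the ring matters as well as their number. Nothing on hand accounts for either step. The compounds shown leave open how an aminomethyl group or a carboxylic acid on this imidazole would read out in this assay.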